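The source may hold more compounds than are shown below. What is called first, only, known or untested is meant among the compounds shown, and "the series" means these compounds.

Compound 1 `Nc1cc(N)c2nc(-c3ccccc3)c(Oc3ccc(Cl)c(Cl)c3)nc2c1`: < 100000 nM (a limit of the assay)
Compound 2 `CCOC(=O)[C@H](CCC(=O)O)NC(=O)c1ccc(Sc2nc3cc(N)cc(N)c3nc2-c2ccccc2)cc1`: 24500 nM
Compound 3 `Nc1cc(N)c2nc(-c3ccccc3)c(Sc3ccc(Cl)c(Cl)c3)nc2c1`: < 100000 nM (a limit of the assay)

These three compounds share one core and were tested in a functional assay on K562 cells (Homo sapiens) for inhibition, read by sulforhodamine B assay, with a stated time of 48 h; on this read-out lower numbers stand for stronger inhibition of growth and higher numbers for weaker inhibition of growth. For compound 1 the result is only a limit of the assay, < 100000 nM. For compound 3 the result is likewise a limit of the assay, < 100000 nM. Compound 2 gives an actual number in this assay, namely 24500 nM. Within the data shown here, the single one-place step among the measured compounds, a step that the two limits leave unreadable from compound 1 to compound 3, cannot be sized because the limit of < 100000 nM in this assay, at which 2 of the 3 values shown sit, covers both of its ends, so nothing can be said about how large it is or which way it runs.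

Compound 4 `Nc1cc(N)c2nc(-c3ccccc3)c(Sc3ccc(F)cc3)nc2c1` has not been measured yet. It differs from compound 3 by 4-fluorophenyl in place of 3,4-dichlorophenyl on a sulfur. Among the measured compounds shown here, no measured step touches this kind of exchange, and compound 3 itself stands only at a limit, so the expectation rests on a weak footing and leans mainly on compound 2 as the one real number. Compound 4 is expected to give about 40000 nM, somewhere between 10000 nM and 100000 nM. The step this estimate implies, a step that the limit leaves unreadable from compound 3 to compound 4, is expected to be small, with no direction claimed beyond the usual scatter.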

Compound 4, concentration for total growth inhibition: 38900 nM
Estimate against measurement, compound 4: 1.0-fold (0.01 log units) above; low and high end bracket the measured number.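

Neither the step from compound 3 to compound 4 nor the one from compound 1 to compound 4 can be read, because compound 1 and compound 3 each stand only at a limit: the limit of < 100000 nM in this assay, at which 2 of the 4 values shown sit.

The compounds shown leave open whether 4-fluorophenyl in place of 3,4-dichlorophenyl on a sulfur changes growth inhibition at all, and in which direction.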